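The compounds below may be only part of what the source reports. "The series", "measured", "known", "first", "only" and "open" are said of these compounds alone.

Going by the values given here, compound 1, with structure `CN(C[C@H]1Cc2c(cccc2N2C[C@H]3CNC[C@H]3C2)CN1)[C@H]1CCCc2cccnc21`, is the one compound here that carries a measured number. Among the compounds with values here, in an ADME assay on microsomes from liver (Mus musculus) for metabolic stability, using NADPH, with a stated time of 10 min (a higher number here means that more of the compound is left, a lower number that less of the compound is left), compound 1 gives 54.7%, which is the only value of its kind in this set. A close relative, compound 2 with structure `CN(C[C@H]1Cc2c(cccc2N2C[C@H]3CCN(C)[C@H]3C2)CN1)[C@H]1CCCc2cccnc21`, has no result in this assay; its entry for compound 2 reads "not determined" (no result reported). Compound 1 is therefore the sole point of reference, and nothing can be said about any gap between these two compounds.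

Compound 3, with structure `CN1C[C@@H]2CN(c3cccc4c3C[C@H](CN(C)[C@H]3CCCc5cccnc53)NC4)C[C@@H]2C1`, has not yet been measured. It differs from compound 1 in a single place: methyl in place of hydrogen on an amine nitrogen in a ring. Everything else in the molecule is kept. Within the data shown here, no pair of measured compounds shows how such a change moves the number in this assay, so the expectation for compound 3 rests only on the value of compound 1 and on how small the change is. A shift of modest size, toward somewhat less of the compound remaining, is expected, and the estimated step of a number 9.7 percentage points lower from compound 1 to compound 3 (within the scatter) may well stay within the usual scatter. Compound 3 is accordingly expected to give about 45% in this assay, within a range from 25% to 65%.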

Compound 3, percent of the compound remaining: 32.9%
The estimate for compound 3 lay 12.1 percentage points above the measured number; the range from low to high includes it.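

In this assay, methyl in place of hydrogen on an amine nitrogen in a ring gives a number 21.8 percentage points lower from compound 1 to compound 3 (beyond the scatter) and so counts as a real shift rather than noise between repeated measurements. Going by these compounds alone, until now there was no measured step at this position, and this one shows that the nitrogen of the five-membered non-aromatic ring is not a neutral place for change: adding a single carbon there leaves clearly less of the compound. No measurement here explains why the number falls.

The compounds shown offer only hydrogen and methyl on this nitrogen, so it remains open how an ethyl group, a longer chain or an acetyl group at the same place would move the number, and whether the fall would grow, level off or reverse. From the compounds shown here alone, a single step is also no pattern, so it remains open whether methyl would have a similar effect on this nitrogen in a compound that differs elsewhere from the core of compound 1.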